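Aryl swap on the phenethyl arm of compound 1

The compounds below may be only part of what the source reports. "The series", "measured", "known", "first", "only" and "open" are said of these compounds alone.

Compound 1 `CCN(CC)CCCC(C)/N=C(/N)NC(=O)c1cccc(F)c1CCc1ccc2ccccc2c1` stands highest of the three in an assay for binding affinity to Melanocortin receptor 4 (Homo sapiens) (a lower number here means a stronger inhibitor, a higher number a weaker inhibitor), at 690 nM. For the measured compounds named here, compound 2 `COc1ccc(Br)cc1CCc1c(F)cccc1C(=O)/N=C(\N)NCCCN1CCCCC1` gives 3.2 nM and compound 3 `COc1ccc(Br)cc1CCc1c(F)cccc1C(=O)/N=C(\N)NCCCCN1CCCCC1` gives 0.58 nM; the only single-point step among measured compounds is a 5.5-fold lower number from compound 2 to compound 3 (0.74 log units; beyond the scatter), which concerns the amine end of the chain, not the aryl end. Compound 4 `CCN(CC)CCCC(C)/N=C(/N)NC(=O)c1cccc(F)c1CCc1ccccc1Cl` is compound 1 with 2-chlorophenyl in place of naphthalen-2-yl on a saturated chain carbon, two bonds along the chain from an aromatic carbon. Going by the values given here, no measured pair isolates this aryl change: compound 2 and compound 3 carry a different aryl and a different amine chain at once, so their far lower numbers cannot be read onto the aryl alone. With nothing that bears on it, the step is expected to stay small, a 1.4-fold higher number from compound 1 to compound 4 (0.16 log units; within the scatter), with wide uncertainty. Compound 4 is therefore estimated at 1000 nM, within 250 nM to 4000 nM.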

Compound 4, inhibition constant: 26000 nM
The estimate for compound 4 lay 26-fold (1.41 log units) below the measured number, and the stated range ends below it.
By their numbers in this assay, from the lowest: compound 3; then compound 2; then compound 1; then compound 4.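

On this saturated chain carbon, two bonds along the chain from an aromatic carbon, the aryl group is not interchangeable: in this assay, 2-chlorophenyl in place of naphthalen-2-yl gives a 38-fold higher number from compound 1 to compound 4 (1.58 log units; beyond the scatter), a large step. For the compounds shown here, the earlier single-point step concerned the amine end of the chain; this is the first reading at the aryl end. No data at hand explain the loss.

Open, from the compounds shown here alone, is whether the second aromatic ring or the chlorine accounts for the step, which plain phenyl on the core of compound 1 would help separate. Also open, going by these compounds, is how 2-chlorophenyl behaves with the piperidin-1-yl chain of compound 3.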